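Prop-1-en-1-yl for vinyl across two acrylamide cores

This account rests on a few compounds, and the source may have more. Where it says the series, first, only, none or still open, it means among the compounds named here.

Compound 1 `C=CC(=O)Nc1ccc(Cn2nc(-c3ccc(Oc4ccccc4)cc3)cc2C(=O)OCC)cc1` carries a vinylcarbonyl amide; in a functional assay on JeKo-1 cells (Homo sapiens) for inhibition, read by luminescence and CellTiter-Glo, with a stated time of 72 h (on this read-out higher numbers stand for weaker inhibition and lower numbers for stronger inhibition), compound 1 gives 10900 nM. Compound 2 `C/C=C/C(=O)Nc1ccc(Cn2nc(-c3ccc(Oc4ccccc4)cc3)cc2C(=O)OCC)cc1` differs by prop-1-en-1-yl in place of vinyl on a carbonyl carbon, and in this assay compound 2 gives 52500 nM, so this change made a 4.8-fold higher number from compound 1 to compound 2 (0.68 log units; beyond the scatter).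

Compound 3 `C=CC(=O)N1CCCC(n2nc(-c3ccc(Oc4ccccc4)cc3)cc2C(=O)O)C1` rests on a different core, and the difference between the two cores is not broken down here. Compound 3 reaches only a limit of this assay, > 60000 nM. Compound 3 sits at the limit of > 60000 nM in this assay, at which 1 of the 3 values shown sits.

Compound 4 `C/C=C/C(=O)N1CCCC(n2nc(-c3ccc(Oc4ccccc4)cc3)cc2C(=O)O)C1` is not yet measured. It differs from compound 3 by prop-1-en-1-yl in place of vinyl on a carbonyl carbon. The place is a carbonyl carbon whose other neighbour is an amide-type nitrogen in a ring, whereas in compound 1 it is an amide-type nitrogen, so the change is of the same kind rather than the same.

Since the same kind of change gave a 4.8-fold higher number from compound 1 to compound 2 (0.68 log units; beyond the scatter), and compound 3 already stands at a limit, the step from compound 3 to compound 4 is estimated as a step that the limit leaves unreadable from compound 3 to compound 4. Compound 4 is expected to give 120000 nM, most likely again reported only as a limit. The expected range for compound 4 runs from 60000 nM to 400000 nM.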

Compound 4, half-maximal inhibitory concentration: > 60000 nM
Compound 4 ended at the assay's limit (the forecaster's own chance of this, stated with the estimate: 90%); the middle value is on the limit's open side.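

Compound 3 and compound 4 both stand at a limit of this assay, and no step between them can be read: the limit of > 60000 nM in this assay, at which 2 of the 4 values shown sit.

The compounds shown leave open whether prop-1-en-1-yl in place of vinyl on a carbonyl carbon shifts the number on the core of compound 3 as it does on the core of compound 1.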